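The source may hold more compounds than are shown below. What is called first, only, known or untested is meant among the compounds shown, and "the series" means these compounds.

Compound 1 `O[C@H]1[C@H](Oc2ccc3ccccc3c2)OCC[C@@H]1O` gives 284 uM in a functional assay on HCC70 cells (Homo sapiens) for antiproliferative activity, read by crystal violet staining, with a stated time of 96 h; a lower number here means that less compound is needed, a higher number that more compound is needed for the effect; compound 2 `O[C@H]1[C@H](Oc2ccc3ccccc3c2)OC[C@@H](O)[C@H]1O` gives 178 uM.

Compound 2 thus has the lower of the two numbers, though the gap to compound 1 is within the scatter, so no order between them can be claimed. Compound 3 `O[C@@H]1[C@@H](O)[C@H](Oc2ccc3ccccc3c2)OC[C@@H]1O` has not been measured. Among the compounds with values here, how it differs from compound 2 is this: the two compounds have the same atoms and bonds and differ only in configuration as drawn: 2 of 4 stereo elements differ; a stereocentre at a saturated ring carbon is drawn R in compound 2 and S in compound 3; a stereocentre at a saturated ring carbon is drawn R in compound 2 and S in compound 3 No measured pair here shows what such a change does, so the size of the step is uncertain; a step of a 1.1-fold higher number from compound 2 to compound 3 (0.05 log units; within the scatter) is expected, which is none beyond the scatter. Compound 3 is accordingly estimated at 200 uM, with a range from 80 uM to 500 uM.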

Compound 3, concentration for half-maximal effect: 371 uM
The estimate for compound 3 lay 1.9-fold (0.27 log units) below the measured number, and the stated range covers the measured number.
By their numbers in this assay, from the lowest: compounds 2, 1 and 3 (each within the scatter of the next, the first and the last beyond it).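

In this assay, within the data shown here, the earlier compounds offered no step beyond the scatter, whereas here there is a 2.1-fold higher number from compound 2 to compound 3 (0.32 log units; beyond the scatter), and its only source is this: the fact that compounds 2 and 3 differ only in the configuration as drawn. Hydroxy in place of hydrogen on a saturated ring carbon comes with a 1.3-fold higher number from compound 1 to compound 3 (0.12 log units; within the scatter), so that exchange establishes no order between its two compounds.

As far as these compounds go, both stereocentres change together in the pair of compound 2 and compound 3, and which of them carries the step stays open. Also open, from the compounds shown here alone, is what an amine in place of a ring hydroxy would do to the number.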